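Exposure notes: from compound 2 to compound 3

A few compounds are considered here, and "the series" means these few. Any claim that something is new, unique, unknown or untested is made for them only; others in the source may bear on it.

In an ADME assay on the whole organism (strain FVB) for pharmacokinetics, with Mus musculus as the target, read by LC-MS, at a dose of 30 mg/kg by the oral route (on this read-out higher numbers stand for higher exposure at the dose given and lower numbers for lower exposure), compound 1 `CC(C)(N)CCOc1ccc([C@H]2CC[C@]3(CC2)OOC2(O3)C3CC4CC(C3)CC2C4)cc1` gives 12300 ng.h/mL and compound 2 `c1cc([C@H]2CC[C@]3(CC2)OOC2(O3)C3CC4CC(C3)CC2C4)ccc1OCCC1CCNCC1` gives 16000 ng.h/mL. Among the compounds with values here, compound 2 therefore stands level with compound 1, its only measured neighbour, and no order between the two can be read from these numbers.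

The next compound, compound 3 `c1cc([C@H]2CC[C@]3(CC2)OOC2(O3)C3CC4CC(C3)CC2C4)ccc1OC1CCNCC1`, keeps the shared core and carries one change: piperidin-4-yl in place of 2-(piperidin-4-yl)ethyl on an oxygen on an aromatic ring. Within the data shown here, no measured step covers this exact change. The nearest evidence is a 1.3-fold higher number from compound 1 to compound 2 (0.11 log units; within the scatter), a replacement on a saturated chain carbon, two bonds along the chain from an oxygen on an aromatic ring. That step altered the side chain without moving this assay beyond the scatter, but it is a single comparison and gives only weak guidance for a change made on the oxygen itself.

No clear direction can be drawn from it, so no shift beyond the scatter is expected. The expected step is a 1.2-fold lower number from compound 2 to compound 3 (0.09 log units; within the scatter). Compound 3 is estimated at 13000 ng.h/mL, with an expected range of 4500 ng.h/mL to 35000 ng.h/mL.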

Compound 3, area under the concentration-time curve: 7200 ng.h/mL
For compound 3 the middle estimate is 1.8-fold (0.26 log units) above the measured one; measured number inside the range.
By their numbers in this assay, from the lowest: compounds 3, 1 and 2 (each within the scatter of the next, the first and the last beyond it).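

Replacing 2-(piperidin-4-yl)ethyl with piperidin-4-yl on an oxygen on an aromatic ring gives, in this assay, a 2.2-fold lower number from compound 2 to compound 3 (0.35 log units; beyond the scatter), a modest move and the only step among these compounds to pass beyond the scatter. Against 3-amino-3-methylbutyl on the same oxygen, the same entering group gives a 1.7-fold lower number from compound 1 to compound 3 (0.23 log units; within the scatter), so its reading at this position depends on which side chain serves as the reference, with one comparison beyond the scatter and the other within it. The measurements on hand offer no explanation for the size of either step.

Still open, from the compounds shown here alone, is whether exposure follows the length of the link between the oxygen and the piperidine, which a longer chain such as 3-(piperidin-4-yl)propyl on the same oxygen would test. Also open, going by these compounds, is whether the piperidine ring matters in itself, which an open-chain primary amine of the same length as the 2-(piperidin-4-yl)ethyl group, or a piperidin-3-yl group on the oxygen, would help to separate from the effect of the link.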